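Swapping the Sulfone for an Azetidine Amide: Solubility Outlook

A few compounds are considered here, and "the series" means these few. Any claim that something is new, unique, unknown or untested is made for them only; others in the source may bear on it.

Compound 1 `CC(C)OC(=O)N1CCC2(CC1)CC(CCCOc1ccc(S(C)(=O)=O)cc1)C2` gives 0.17 ug/mL in a physicochemical assay for solubility, read by HPLC, in phosphate buffer, with a stated time of 24 h, at pH 6.8; on this read-out higher numbers stand for higher solubility and lower numbers for lower solubility. Compound 2 `CC(C)OC(=O)N1CCC2(CC1)CC(CCCOc1ccc(S(C)(=O)=O)c(F)c1)C2` carries fluoro in place of hydrogen on an aromatic carbon of that structure. In this assay compound 2 gives < 0.16 ug/mL, which is a limit of the assay rather than a number. The step from its parent is an at least 1.0-fold lower number from compound 1 to compound 2 (0.02 log units; that floor lies within the scatter). Compound 3 `CS(=O)(=O)c1ccc(OCCCC2CC3(CCN(C(=O)OC4CCCC4)CC3)C2)cc1F` carries cyclopentyl in place of isopropyl on an oxygen next to a carbonyl group. In this assay compound 3 gives < 0.14 ug/mL, again a limit. The step that the two limits leave unreadable from compound 2 to compound 3 cannot be sized. Compound 2 therefore stands at the limit of < 0.16 ug/mL in this assay, at which 1 of the 3 values shown sits, with compound 3 at the limit of < 0.14 ug/mL in this assay, at which 1 of the 3 values shown sits, and only compound 1 carrying an actual number.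

Compound 4 `CC(C)OC(=O)N1CCC2(CC1)CC(CCCOc1ccc(C(=O)N3CCC3)c(F)c1)C2` differs from compound 2 as follows: (azetidin-1-yl)carbonyl in place of methylsulfonyl on an aromatic carbon. Neither measured step touches this position: one concerns the fluoro group and the other the carbamate ester, and both leave compound 2 and compound 3 at limits. Among the compounds with values here, no measured step bears directly on the change, so the expectation is loose and rests on compound 2 sitting at a floor. The step from compound 2 to compound 4 is expected to be an at least 2.5-fold higher number from compound 2 to compound 4 (0.39 log units; beyond the scatter), in the direction of higher solubility if any. Compound 4 is estimated at 0.4 ug/mL, with a range from 0.1 ug/mL to 2 ug/mL.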

Compound 4, solubility: 3.43 ug/mL
The estimate for compound 4 lay 8.6-fold (0.93 log units) below the measured number; measured number above the stated range.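

In this assay, (azetidin-1-yl)carbonyl in place of methylsulfonyl, on the aromatic carbon ortho to a fluoro group, gives an at least 21-fold higher number from compound 2 to compound 4 (1.33 log units; beyond the scatter). The two earlier steps concerned other places and either stayed within the scatter or could not be read, so this position is the only place among those shown where a change moves the number clear of a limit. The size of this step is only a floor, since compound 2, where it starts, is a limit and not a number: the limit of < 0.16 ug/mL in this assay, at which 1 of the 4 values shown sits.

The compounds shown do not separate the contribution of the carbonyl from that of the four-membered ring, and a pyrrolidine amide, a morpholine amide or an open-chain dimethylamide at this position would bear on that question. They also leave open whether the same exchange would lift the number when the fluoro group is absent, as in compound 1, or when cyclopentyl stands in place of isopropyl, as in compound 3.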